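This account rests on a few compounds, and the source may have more. Where it says the series, first, only, none or still open, it means among the compounds named here.

Measured so far in an assay on HEK293 cells for displacement of a labelled ligand from corticotropin-releasing factor receptor 1 (Homo sapiens); on this read-out lower numbers stand for stronger inhibition and higher numbers for weaker inhibition:
Compound 1, `CCCCCN(CC1CC1)c1cc(C)nc2c(-c3ccc(Cl)cc3Cl)nn(C)c12`, gives 1.5 nM.
Compound 2, `CCCCN(CCCC)c1cc(C)nc2c(-c3ccc(Cl)cc3Cl)nn(C)c12`, gives 0.62 nM.

Compound 2 has the lowest number of the two; compound 1 sits a step higher, beyond the scatter. Compound 3, `CCCCCN(CCCC)c1cc(C)nc2c(-c3ccc(Cl)cc3Cl)nn(C)c12`, differs from compound 2 by methyl in place of hydrogen on a saturated chain carbon, four bonds along the chain from a nitrogen on an aromatic ring. Within the data shown here, no measured pair shows this change, so its effect is not known from these data. The expectation for the step from compound 2 to compound 3 in this assay is a small one, if any, and not clearly beyond the scatter: a 1.3-fold higher number from compound 2 to compound 3 (0.11 log units; within the scatter). Compound 3 is therefore estimated at 0.8 nM, with a range from 0.3 nM to 2.5 nM.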

Compound 3, inhibition constant: 0.9 nM
Compound 3: the middle estimate sits 1.1-fold (0.05 log units) below what was measured, within the range that was stated.
By their numbers in this assay, from the lowest: compounds 2, 3 and 1 (each within the scatter of the next, the first and the last beyond it).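

In this assay, methyl in place of hydrogen on a saturated chain carbon, four bonds along the chain from a nitrogen on an aromatic ring, now has a measured effect: a 1.5-fold higher number from compound 2 to compound 3 (0.16 log units; within the scatter). Propyl in place of cyclopropyl on a saturated chain carbon bound to a nitrogen on an aromatic ring gives a 1.7-fold lower number from compound 1 to compound 3 (0.22 log units; within the scatter), so neither change moves the number beyond the scatter. No measurement is available that bears on the reason for these steps. The compounds shown leave open whether a longer chain, a hydroxyl or an amine in place of this methyl would also stay within the scatter of compound 2.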